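Series notes: small alkyl step from compound 3 to compound 4

The source may hold more compounds than are shown below. What is called first, only, known or untested is meant among the compounds shown, and "the series" means these compounds.

Measured so far in an in vitro functional assay on Sf9 cells for antagonist activity at histamine H2 receptor (Homo sapiens); a higher number here means a more potent compound, by a factor of ten per unit of this negative logarithm, a lower number a less potent compound:
- compound 1 `N#C/N=C(/NCCCCc1c[nH]cn1)NCCCc1ccccn1` gives 5.48
- compound 2 `CC(CCN/C(=N\C#N)NCCCCc1c[nH]cn1)c1ccccc1` gives < 5
- compound 3 `CN/C(=N\C#N)NCCCCc1c[nH]cn1` gives < 5

Compound 3 stands at the bottom of the set: its value in this assay is a limit, not a number. The same holds for compound 2, so that two of the three results sit at the limit of < 5 in this assay, at which 2 of the 3 values shown sit, and only compound 1 carries a measured number.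

Compound 4 `CCN/C(=N\C#N)NCCCCc1c[nH]cn1` differs from compound 3 by methyl in place of hydrogen on a saturated chain carbon bound to an amine nitrogen. Both measured steps run from compound 1 and involve the substituent on the chain leading away from the amine nitrogen: a number at least 0.48 log units lower from compound 1 to compound 3 (beyond the scatter), where the whole 2-(pyridin-2-yl)ethyl group is removed, and a number at least 0.48 log units lower from compound 1 to compound 2 (beyond the scatter), where the ring-bearing group is exchanged. Both are losses, and both end at the limit of this assay. The change from compound 3 to compound 4 is far smaller than either of these and stays on the same chain carbon, so no step beyond the scatter is expected; the estimated change is a step that the limit leaves unreadable from compound 3 to compound 4.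

Compound 4 is therefore expected near the limit, with an estimated value of 4.8 in this assay, in the range 4.2 to 5.4.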

Compound 4, negative logarithm of the antagonist equilibrium constant: < 5
Compound 4 ended at the assay's limit; the forecaster's own chance of this, stated with the estimate: 65%; the middle value lies beyond the limit too.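

Lengthening the end group from the methylamino of compound 3 to the ethylamino of compound 4 does not bring a measurable value into reach in this assay, and compound 4 gives < 5, which is a limit and not a number. The small alkyl group on this saturated chain carbon bound to an amine nitrogen therefore stands on the same side of the loss as hydrogen does, and the step from the ring-bearing chain is a number at least 0.48 log units lower from compound 1 to compound 4 (beyond the scatter). The steps joining compound 4 to compound 3 and to compound 2 cannot be read, and the low end of the series now holds most of the compounds shown: the limit of < 5 in this assay, at which 3 of the 4 values shown sit.

Compound 1 remains the only compound with a measured number, 5.48, and the compounds shown do not separate the part played by the pyridin-2-yl group from that of the chain carrying it. From the compounds shown here alone, whether a plain propyl or butyl chain at this position, without a ring, or a phenyl group on the unbranched chain of compound 1, would rise clear of the limit stays open.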